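Swapping a Benzyl Group for a Thiourea on the Ring Nitrogen

The source may report more compounds than this note shows. Statements on the series, on what has been measured and on what is new or still open speak of the compounds shown alone.

Measured so far:
Compound 1, `N#Cc1ccccc1CN1CCc2c(sc(NC(=O)c3ccccc3Cl)c2C(N)=O)C1`: 10400 nM
Compound 2, `NC(=O)c1c(NC(=O)c2cccc([N+](=O)[O-])c2)sc2c1CCN(Cc1c(Cl)cccc1Cl)C2`: 18400 nM

Both compounds were tested in a functional assay on HL-60 cells (Homo sapiens) for antiproliferative activity, with a stated time of 24 h; a lower number here means a stronger inhibitor, a higher number a weaker inhibitor. Compound 1 gives 10400 nM and compound 2 gives 18400 nM; these two numbers lie within the usual scatter of each other, so neither stands apart from the other. Compound 1 is therefore simply one of two weak inhibitors, not a clear front-runner.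

Compound 3, `Cc1ccccc1NC(=S)N1CCc2c(sc(NC(=O)c3ccccc3Cl)c2C(N)=O)C1`, has not yet been measured. Compared with compound 1 it differs in one place: a group of 10 heavy atoms (8 carbon, 1 nitrogen, 1 sulfur; one six-membered aromatic ring of carbon only) in place of a group of 9 heavy atoms (8 carbon, 1 nitrogen; one six-membered aromatic ring of carbon only), on an amine nitrogen in a ring. The amide and the chlorinated benzamide on the shared core stay the same.

Within the data shown here, no step between two measured compounds shows what such a change on the ring nitrogen does. The expectation rests on compound 1 alone. The step of a 1.2-fold lower number from compound 1 to compound 3 (0.06 log units; within the scatter) is expected to be small, with no clear direction beyond the scatter. Compound 3 is estimated at 9000 nM, in a range from 2500 nM to 32000 nM.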

Compound 3, half-maximal inhibitory concentration: 22600 nM
Estimate against measurement, compound 3: 2.5-fold (0.40 log units) below; the measured number falls inside the stated range.
By their numbers in this assay, from the lowest: compounds 1, 2 and 3 (each within the scatter of the next, the first and the last beyond it).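

In this assay, replacing the 2-cyanobenzyl group on the ring nitrogen with the thiourea gives a 2.2-fold higher number from compound 1 to compound 3 (0.34 log units; beyond the scatter). Among these compounds, this is the first measured change at this position, and it shows that the thiourea does not improve on the 2-cyanobenzyl group here: the number moves modestly, towards weaker inhibition. Nothing measured here explains the direction or size of this step.

On these data alone, with a single step at this nitrogen, it remains open whether the difference follows from the thiourea link itself or from the ring attached to it and the loss of the nitrile. A urea, with oxygen in place of the sulfur, or a plain benzyl group without the nitrile, could help separate these possibilities on the same shared core.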